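The source may hold more compounds than are shown below. What is called first, only, known or untested is meant among the compounds shown, and "the series" means these compounds.

Compound 3 `CCOc1ccccc1N/N=C1\CCC(C)n2c1ncc(C(=O)O)c2=O` in a functional assay on the whole organism for inhibition, with Rattus norvegicus as the target (a lower number here means that less compound is needed, a higher number that more compound is needed for the effect), gives > 1000 umol/kg, which is a limit of the assay and not a number. Compound 1 `CC1CC/C(=N\Nc2ccccc2F)c2ncc(C(=O)O)c(=O)n21` in this assay gives > 1000 umol/kg, likewise a limit. Compound 2 `CC1CC/C(=N\Nc2ccccc2Br)c2ncc(C(=O)O)c(=O)n21` in this assay gives > 320 umol/kg, again a limit. None of the three values shown is a number: two sit at the limit of > 1000 umol/kg in this assay, at which 2 of the 3 values shown sit, and one at the limit of > 320 umol/kg in this assay, at which 1 of the 3 values shown sits. The change to compound 4 `CC(=O)c1ccccc1N/N=C1\CCC(C)n2c1ncc(C(=O)O)c2=O` is acetyl in place of ethoxy on an aromatic carbon. The measured steps bearing on this position, a step that the two limits leave unreadable from compound 1 to compound 3, a step that the two limits leave unreadable from compound 2 to compound 3 and a step that the two limits leave unreadable from compound 1 to compound 2, all have no readable size, so the series gives no direction and no size to expect for the new step in this assay beyond the scatter. Compound 4 is expected to give about 1000 umol/kg in this assay, with a range from 300 umol/kg to 3000 umol/kg, and most probably again only a limit. The expected step of a number no higher from compound 3 to compound 4 (the limit leaves the size open) is thus estimated to be within the scatter.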

Compound 4, dose for 50% inhibition: > 1000 umol/kg
Compound 4: only a limit was reported (the forecaster's own chance of this, stated with the estimate: 80%); the middle value lies on the limit itself.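

In this assay compound 4 gives > 1000 umol/kg, a limit of the assay and not a number, and the steps linking compound 4 to compound 1, compound 2 and compound 3 cannot be read. The compounds shown leave open whether fluoro, bromo, ethoxy or acetyl on the aromatic carbon makes any difference in this assay.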